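This account rests on a few compounds, and the source may have more. Where it says the series, first, only, none or still open, it means among the compounds named here.

Compound 1 `CCc1ccc(Cn2c(CCc3ccccc3)nnc2[C@H](NC(=O)c2ccccn2)c2c[nH]c3ccccc23)cc1` gives 67 nM in an in vitro assay on LLC-PK1 cells for displacement of a labelled ligand from growth hormone secretagogue receptor type 1 (Homo sapiens); on this read-out lower numbers stand for stronger inhibition and higher numbers for weaker inhibition.
Compound 2 `CCc1ccc(Cn2c(CCc3ccccc3)nnc2[C@H](NC(=O)Cc2ccccn2)c2c[nH]c3ccccc23)cc1` gives 51 nM in this assay.
Compound 3 `CCc1ccc(Cn2c(CCc3ccccc3)nnc2[C@H](NC(=O)Cc2cccnc2)c2c[nH]c3ccccc23)cc1` gives 480 nM in this assay.

Of these three, compound 3 shows the highest number: it sits a 7.2-fold higher number from compound 1 to compound 3 (0.86 log units; beyond the scatter) and a 9.4-fold higher number from compound 2 to compound 3 (0.97 log units; beyond the scatter), both steps beyond the scatter, while compounds 1 and 2 lie within the scatter of each other, as a 1.3-fold lower number from compound 1 to compound 2 (0.12 log units; within the scatter) shows. Compound 4 `CCc1ccc(Cn2c(CCc3ccccc3)nnc2[C@H](NC(=O)c2cnccn2)c2c[nH]c3ccccc23)cc1` differs from compound 3 by one change: pyrazin-2-yl in place of (pyridin-3-yl)methyl on a carbonyl carbon. For the measured compounds named here, the step that bears most on this is the one between compound 1 and compound 3, where a six-membered aromatic ring placed directly on the carbonyl carbon gave a far lower number than the same kind of ring set one carbon further out, and compound 4 again carries its ring directly on the carbonyl carbon. Going by the values given here, no measured compound carries a ring with two hetero atoms, so that part of the change is untested. On this basis compound 4 is expected to show a 4.8-fold lower number from compound 3 to compound 4 (0.68 log units; beyond the scatter), an estimated 100 nM with a range from 30 nM to 350 nM.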

Compound 4, half-maximal inhibitory concentration: 89 nM
The estimate for compound 4 lay 1.1-fold (0.05 log units) above the measured number, within the range that was stated.
By their numbers in this assay, from the lowest: compounds 2, 1 and 4 (each within the scatter of the next); then compound 3.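

In this assay, for the compounds shown here, a ring with two hetero atoms now stands on the carbonyl carbon for the first time, and pyrazin-2-yl in place of (pyridin-3-yl)methyl gives a 5.4-fold lower number from compound 3 to compound 4 (0.73 log units; beyond the scatter), a step beyond the scatter. Against the two other amides, compound 4 cannot be told apart, with a 1.3-fold higher number from compound 1 to compound 4 (0.12 log units; within the scatter) and a 1.7-fold higher number from compound 2 to compound 4 (0.24 log units; within the scatter), so the second ring nitrogen of pyrazin-2-yl leaves the number within the scatter of pyridin-2-yl on this carbon, and only compound 3 stands apart among the four. No measurement at hand speaks to the reason for this.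

Still open, as far as these compounds go, is how a pyridin-3-yl or a plain phenyl ring on the carbonyl carbon would compare. Also open, from the compounds shown here alone, is whether a (pyrazin-2-yl)methyl group would fall with compound 2 or with compound 3.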